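The source may hold more compounds than are shown below. What is called first, only, known or untested is meant among the compounds shown, and "the series" means these compounds.

In a functional assay on MV4-11 cells (Homo sapiens) for antiproliferative activity, read by CellTiter-Glo, with a stated time of 72 h (on this read-out higher numbers stand for weaker inhibition of growth and lower numbers for stronger inhibition of growth), compound 1 `COCCN[C@H]1CC[C@H](Nc2cc(-c3csc(NCC4CCOCC4)n3)c(Cl)cn2)CC1` gives 170 nM while compound 2 `COCCN[C@H]1CC[C@H](Nc2cc(-c3csc(NCC4CCCC4)n3)c(Cl)cn2)CC1` gives 2160 nM as the higher of the two numbers, which marks it as the weaker inhibitor of growth in this pair. Compound 3 `COCCN[C@H]1CC[C@H](Nc2cc(-c3csc(NCC4CCOC4)n3)c(Cl)cn2)CC1` has not yet been measured. It differs from compound 2 in one place, described as oxolan-3-yl in place of cyclopentyl on a saturated chain carbon bound to a nitrogen on an aromatic ring with oxolan-3-yl in place of cyclopentyl on a saturated chain carbon bound to a nitrogen on an aromatic ring. Within the data shown here, one measured step bears on this change, namely a 13-fold higher number from compound 1 to compound 2 (1.10 log units; beyond the scatter) with cyclopentyl in place of oxan-4-yl, and it is large and beyond the scatter. Read in reverse, that step points to a lower number for compound 3. However, oxolan-3-yl is not oxan-4-yl, and no measured compound carries it, so only part of that size is expected to return. The expected change is a 6.2-fold lower number from compound 2 to compound 3 (0.79 log units; beyond the scatter) in this assay as an estimate resting on that single step. Compound 3 is expected at 350 nM with 120 nM to 1000 nM as its estimated range.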

Compound 3, concentration for 50% growth inhibition: 493 nM
Compound 3: middle estimate off by 1.4-fold (0.15 log units), on the low side; the measured number falls inside the stated range.
By their numbers in this assay, from the lowest: compound 1; then compound 3; then compound 2.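

With the ring size held at five members, exchanging one ring carbon for an oxygen at this place on a saturated chain carbon bound to a nitrogen on an aromatic ring still gives a 4.4-fold lower number from compound 2 to compound 3 (0.64 log units; beyond the scatter) in this assay, so the lower number seen with compound 1 does not depend on a six-membered ring. Oxolan-3-yl does not match oxan-4-yl, however, as a 2.9-fold higher number from compound 1 to compound 3 (0.46 log units; beyond the scatter) shows, and among these three compounds the order therefore depends on which oxygen-bearing ring is present as well as on whether the ring carries an oxygen at all, with neither oxygen-bearing ring falling to the level of the carbon-only cyclopentyl of compound 2. Nothing available gives a reason for these differences in growth inhibition.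

Compound 1 and compound 3 differ in both ring size and the point at which the ring is attached, so the compounds shown do not separate those two contributions. As far as these compounds go, it also remains open how cyclohexyl or oxan-3-yl would read at this place, and whether a piperidin-4-yl ring, with an amine nitrogen in place of the oxygen, would follow the oxygen-bearing rings or cyclopentyl.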